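Amide aryl swapped for furan-2-yl at the anilide carbonyl

The compounds below may be only part of what the source reports. "The series", "measured", "known", "first", "only" and "open" are said of these compounds alone.

Compound 2 `CN1CCN(c2ccc(Nc3nc(-c4cccc(NC(=O)c5ccc(F)c(Cl)c5)c4)sc3C(N)=O)cc2)CC1` gives 94.4% in a functional assay on Raji cells (Homo sapiens) for antiproliferative activity, read by CCK-8 assay, with a stated time of 72 h, tested at 40 uM; a higher number here means more inhibition at the concentration tested (going by the name of the read-out), a lower number less inhibition; compound 1 `CN1CCN(c2ccc(Nc3nc(-c4cccc(NC(=O)c5ccc(C(F)(F)F)cc5)c4)sc3C(N)=O)cc2)CC1` gives 91.9%, and the two sit within the scatter of each other. Compound 3 `CN1CCN(c2ccc(Nc3nc(-c4cccc(NC(=O)c5ccco5)c4)sc3C(N)=O)cc2)CC1` differs from compound 2 by furan-2-yl in place of 3-chloro-4-fluorophenyl on a carbonyl carbon. Within the data shown here, the only step touching the same carbonyl carbon, a number 2.5 percentage points higher from compound 1 to compound 2 (within the scatter), exchanged one six-membered aromatic ring of carbon only for another and stayed within the scatter; no step exchanges the ring type. Compound 3 is therefore expected to remain near compound 2, with a step of a number 9.4 percentage points lower from compound 2 to compound 3 (within the scatter) expected not beyond the scatter. For compound 3 the estimate is 85%, range 55% to 98%.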

Compound 3, a percentage reported as inhibition, at one concentration (the size of the read-out at that concentration, not a potency): 84.3%
For compound 3 the middle estimate is 0.7 percentage points above the measured one, and the stated range covers the measured number.
By their numbers in this assay, from the lowest: compounds 3, 1 and 2 (each within the scatter of the next, the first and the last beyond it).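

In this assay, exchanging the six-membered aromatic ring on the carbonyl carbon for furan-2-yl gives a number 10.1 percentage points lower from compound 2 to compound 3 (beyond the scatter), whereas the same exchange from the other aryl amide gives a number 7.6 percentage points lower from compound 1 to compound 3 (within the scatter). The result of this ring exchange therefore depends on the aryl group it replaces, and compound 3 still gives 84.3% with the smaller five-membered ring. Nothing available bears on the reason for the size of these steps.

On these data alone, whether a saturated ring such as piperidine or a straight alkyl chain can replace the aromatic ring at this carbonyl carbon remains open. So does the effect of an amine or a carboxylic acid on that ring.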